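The source may hold more compounds than are shown below. What is called first, only, known or untested is meant among the compounds shown, and "the series" means these compounds.

Measured compounds so far, all in an ADME assay on 184B5 cells (Homo sapiens) for cytotoxicity, read by sulforhodamine B assay, with a stated time of 48 h; a higher number here means a weaker inhibitor of growth, a lower number a stronger inhibitor of growth:
- compound 3, `CN(C)CN1C(=O)C(=O)c2c(Br)cccc21`, gives 77900 nM
- compound 1, `CCN(CC)CN1C(=O)/C(=N\c2nc3ccc(C)cc3s2)c2c(Br)cccc21`, gives 34300 nM
- compound 2, `O=C1C(=O)N(CN(c2ccccc2)c2ccccc2)c2ccccc21`, gives 33700 nM

Compound 3 has the highest number of the three in this assay. Its nearest neighbour is compound 1, and the gap to it lies beyond the usual scatter; the gap to compound 2 is of the same size and likewise beyond the scatter. Compound 4, `O=C1C(=O)N(CN2CCCCC2)c2cccc(Br)c21`, is not yet measured in this assay. It differs from compound 3 in one place: piperidin-1-yl in place of dimethylamino on a saturated chain carbon bound to an amide-type nitrogen in a ring. Among the compounds with values here, no pair of measured compounds differs only in this way, so the size of such a step is unknown. Compounds 1 and 2 carry other amines on the corresponding chain carbon and both sit at lower numbers than compound 3, but each also differs from it elsewhere, so they give only a loose hint. A modest step toward a lower number is expected for compound 4, possibly only just beyond the scatter, as a 1.7-fold lower number from compound 3 to compound 4 (0.24 log units; within the scatter). Compound 4 is estimated at 45000 nM in this assay, with a range from 20000 nM to 100000 nM.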

Compound 4, concentration for 50% growth inhibition: 85200 nM
The estimate for compound 4 lay 1.9-fold (0.28 log units) below the measured number; the range from low to high includes it.
By their numbers in this assay, from the lowest: compounds 2 and 1 (each within the scatter of the next); then compounds 3 and 4 (each within the scatter of the next).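

In this assay, within the data shown here, the swap of dimethylamino for piperidin-1-yl on a saturated chain carbon bound to an amide-type nitrogen in a ring gives a 1.1-fold higher number from compound 3 to compound 4 (0.04 log units; within the scatter) and is the only single-place reading at this position so far. On this core, then, replacing the open dimethylamino with a six-membered non-aromatic ring leaves the growth-inhibition number unchanged within the scatter, so this change gives no handle on the read-out. No measurement shown accounts for the flat step.

Going by these compounds, it remains open whether an amine with a second ring hetero atom, such as morpholin-4-yl, or a carboxylic acid in this place would move the number beyond the scatter. A longer chain between this amine and the ring nitrogen is equally untested by the compounds shown.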